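Compound 3: 2-phenylethenyl in place of neopentyl

This account rests on a few compounds, and the source may have more. Where it says the series, first, only, none or still open, it means among the compounds named here.

In a toxicity assay on KB cells (Homo sapiens) for cytotoxicity, read by fluorescence, with a stated time of 3 days (on this read-out lower numbers stand for an effect already at smaller amounts and higher numbers for an effect only at larger amounts of compound), compound 1 (`CCCCOC(=O)CNC(=O)[C@H](CSc1ccc([N+](=O)[O-])cc1[N+](=O)[O-])NC(=O)CC[C@H](NC(=O)CCc1c[nH]c2ccccc12)C(=O)OCCCC`) gives 26 uM and compound 2 (`CCCCOC(=O)CNC(=O)[C@H](CSc1ccc([N+](=O)[O-])cc1[N+](=O)[O-])NC(=O)CC[C@H](NC(=O)CC(C)(C)C)C(=O)OCCCC`) gives 250 uM as the highest of the two numbers. Compound 3 (`CCCCOC(=O)CNC(=O)[C@H](CSc1ccc([N+](=O)[O-])cc1[N+](=O)[O-])NC(=O)CC[C@H](NC(=O)/C=C/c1ccccc1)C(=O)OCCCC`) carries 2-phenylethenyl in place of neopentyl on a carbonyl carbon. Within the data shown here, one measured step bears on this change, tert-butyl in place of (1H-indol-3-yl)methyl (a 9.6-fold higher number from compound 1 to compound 2 (0.98 log units; beyond the scatter)), and it is a single pair. Compound 3 regains an aromatic ring, so a smaller step towards lower numbers is expected in this assay. The expected step is a 3.6-fold lower number from compound 2 to compound 3 (0.55 log units; beyond the scatter) on this estimate. For compound 3 the estimated value is 70 uM (expected range 20 uM to 200 uM).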

Compound 3, concentration for half-maximal effect: 34.4 uM
The estimate for compound 3 lay 2.0-fold (0.31 log units) above the measured number, within the range that was stated.
By their numbers in this assay, from the lowest: compounds 1 and 3 (each within the scatter of the next); then compound 2.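

In this assay, 2-phenylethenyl in place of neopentyl gives a 7.3-fold lower number from compound 2 to compound 3 (0.86 log units; beyond the scatter), showing that this position responds to a group other than the indole-bearing one. Replacing 2-(1H-indol-3-yl)ethyl with 2-phenylethenyl gives a 1.3-fold higher number from compound 1 to compound 3 (0.12 log units; within the scatter), so the indole ring system is not required to stay within the scatter of compound 1. Nothing available explains either step.

Whether the aromatic ring or the double bond accounts for the step from neopentyl remains open; a saturated 2-phenylethyl group would separate them. On these data alone, the effect of an amine on the phenyl ring is also open.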